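A 4-chlorophenyl swap on the amine nitrogen

This account rests on a few compounds, and the source may have more. Where it says the series, first, only, none or still open, it means among the compounds named here.

Within the data shown here, in a functional assay on L1210 cells (Mus musculus) for inhibition (on this read-out lower numbers stand for stronger inhibition and higher numbers for weaker inhibition), compound 1 (`C#CCN(Cc1ccc2nc(C)nc(O)c2c1)c1cccc(CO)c1`) gives 48000 nM as the only actual number so far. Compound 2 (`C#CCN(Cc1ccc2nc(C)nc(O)c2c1)c1cccc(C(F)(F)F)c1`) stands only as a limit at > 2200 nM and not as a number. Compound 3 (`C#CCN(Cc1ccc2nc(C)nc(O)c2c1)c1ccc(Cl)cc1`) is still unmeasured, and its difference from compound 1 is 4-chlorophenyl in place of 3-(hydroxymethyl)phenyl on an amine nitrogen with 4-chlorophenyl in place of 3-(hydroxymethyl)phenyl on an amine nitrogen. Among the measured compounds shown here, the sole measured step, a step that the limit leaves unreadable from compound 1 to compound 2 with trifluoromethyl in place of hydroxymethyl, has no readable size, so it offers no firm guide. A modest move toward stronger inhibition in this assay is nonetheless expected, with a 2.4-fold lower number from compound 1 to compound 3 (0.38 log units; beyond the scatter) as the estimated step. For compound 3 the estimated value is 20000 nM within an expected range of 4000 nM to 80000 nM on this thin evidence.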

Compound 3, half-maximal inhibitory concentration: > 4000 nM
Compound 3 gave a limit, no number (the forecaster's own chance of this, stated with the estimate: 35%); the middle value is on the limit's open side.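

In this assay compound 3 gives > 4000 nM, a limit and not a number, so its step from compound 1 cannot be read. The compounds shown leave open whether 4-chlorophenyl in place of 3-(hydroxymethyl)phenyl strengthens or weakens inhibition.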